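A Hydroxypiperidine on the Sulfonyl Sulfur

A few compounds are considered here, and "the series" means these few. Any claim that something is new, unique, unknown or untested is made for them only; others in the source may bear on it.

In an ADME assay on microsomes from liver (Homo sapiens) for pharmacokinetics, read by LC-MS, with a stated time of 60 min, tested at 1 uM (a lower number here means slower removal, a higher number faster removal of the compound), compound 1 `O=C(NCc1ccc(S(=O)(=O)c2cncc(C(F)(F)F)c2)cc1)N1Cc2ccncc2C1` gives 13 mL/min/kg and compound 2 `CN1CCC(S(=O)(=O)c2ccc(CNC(=O)N3Cc4ccncc4C3)cc2)CC1` gives 11 mL/min/kg as its reading, so the two stand within the scatter of each other. Compound 3 `O=C(NCc1ccc(S(=O)(=O)N2CCC(O)CC2)cc1)N1Cc2ccncc2C1` differs from compound 2 in one place: 4-hydroxypiperidin-1-yl in place of 1-methylpiperidin-4-yl on a sulfonyl sulfur. Within the data shown here, only one measured step bears on this place, a 1.2-fold lower number from compound 1 to compound 2 (0.07 log units; within the scatter) when 1-methylpiperidin-4-yl replaced 5-(trifluoromethyl)pyridin-3-yl, and it stays within the scatter. Among the measured compounds shown here, no measured compound yet carries 4-hydroxypiperidin-1-yl, so this single step is a thin guide. No change beyond the scatter is therefore expected in this assay for this replacement. The expected step is a 1.1-fold higher number from compound 2 to compound 3 (0.04 log units; within the scatter) on this estimate, which lies within the scatter. Compound 3 is estimated at 12 mL/min/kg (expected range 6 mL/min/kg to 24 mL/min/kg).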

Compound 3, clearance: 6 mL/min/kg
For compound 3 the middle estimate is 2.0-fold (0.30 log units) above the measured one; the measured number falls inside the stated range.
By their numbers in this assay, from the lowest: compounds 3, 2 and 1 (each within the scatter of the next, the first and the last beyond it).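

Among these compounds, with 4-hydroxypiperidin-1-yl on the sulfonyl sulfur, this assay gives the first step at this position that passes the scatter: replacing 5-(trifluoromethyl)pyridin-3-yl with this group gives a 2.2-fold lower number from compound 1 to compound 3 (0.34 log units; beyond the scatter), a modest change. Set against 1-methylpiperidin-4-yl, the same group gives a 1.8-fold lower number from compound 2 to compound 3 (0.26 log units; within the scatter), which stays within the scatter, so the two six-membered rings cannot be told apart in this read-out. Among the compounds shown here, only the step from the aromatic group to 4-hydroxypiperidin-1-yl therefore stands out, while the earlier step to 1-methylpiperidin-4-yl did not.

Still open, as far as these compounds go, is how a plain piperidin-1-yl, a morpholin-4-yl or a 4-aminopiperidin-1-yl on the same sulfonyl sulfur would read in this assay, and whether the hydroxyl itself matters. No measurement shown here accounts for either step.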